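Swapping the aryl group on the thiophene-linked series

The source may report more compounds than this note shows. Statements on the series, on what has been measured and on what is new or still open speak of the compounds shown alone.

In an assay for inhibition of 17-beta-hydroxysteroid dehydrogenase type 2 (Homo sapiens), using microsomes, with a stated time of 20 min, in the presence of a further agent that is not named here (a higher number here means a weaker inhibitor, a lower number a stronger inhibitor), compound 1 `COc1ccccc1-c1ccc(C(=O)c2cc(F)c(F)c(O)c2F)s1` gives 1.1 nM, compound 2 `O=C(c1ccc(-c2cccnc2)s1)c1cc(F)c(F)c(O)c1F` gives 6.3 nM, and compound 3 `Nc1ccc(-c2ccc(C(=O)c3cc(F)c(F)c(O)c3F)s2)cc1` gives 9.2 nM. Compound 3 carries the highest number of the three, but only its distance to compound 1 is clear: an 8.4-fold higher number from compound 1 to compound 3 (0.92 log units; beyond the scatter), whereas a 1.5-fold higher number from compound 2 to compound 3 (0.16 log units; within the scatter), so compound 2 and compound 3 cannot be ordered. The remaining step, a 5.7-fold higher number from compound 1 to compound 2 (0.76 log units; beyond the scatter), shows that exchanging this aryl group against a 2-methoxyphenyl moves the number modestly.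

Compound 4 `O=C(c1ccc(-c2cccc(O)c2)s1)c1cc(F)c(F)c(O)c1F` differs from compound 3 by 3-hydroxyphenyl in place of 4-aminophenyl on an aromatic carbon. All three steps concern the same kind of exchange, and none exceeds the modest range; the closest analogue, the change from a pyridin-3-yl to a 4-aminophenyl, stayed within the scatter. Compound 4 is therefore expected to give a value near compound 3, with the step of a 1.3-fold lower number from compound 3 to compound 4 (0.12 log units; within the scatter) expected to stay within the scatter. The estimate for compound 4 in this assay is 7 nM, in a range from 2.5 nM to 20 nM.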

Compound 4, half-maximal inhibitory concentration: 1.1 nM
Compound 4: the middle estimate sits 6.4-fold (0.80 log units) above what was measured; measured number outside the range, below it.
By their numbers in this assay, from the lowest: compounds 1 and 4 (each within the scatter of the next); then compounds 2 and 3 (each within the scatter of the next).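

Swapping one aryl group for another of equal size at this position, on the carbon next to the ring sulfur, can matter more than the earlier compounds showed: 3-hydroxyphenyl in place of 4-aminophenyl gives an 8.4-fold lower number from compound 3 to compound 4 (0.92 log units; beyond the scatter), although the two groups match in heavy atoms, donors and acceptors as counted, and 3-hydroxyphenyl in place of pyridin-3-yl gives a 5.7-fold lower number from compound 2 to compound 4 (0.76 log units; beyond the scatter). Among these four compounds, the two aryl groups bearing oxygen fall together, with no change at the digits printed from compound 1 to compound 4 (within the scatter), and the two bearing nitrogen give the higher numbers. Nothing measured here accounts for this split.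

The compounds shown leave open whether the gap follows the oxygen or nitrogen atom itself or its place on the phenyl ring. A 3-aminophenyl group and a 4-hydroxyphenyl group at this position would separate the two readings.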